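The compounds below may be only part of what the source reports. "The series", "measured", "known", "first", "only" and "open" are said of these compounds alone.

In a functional assay on U-937 cells (Homo sapiens) for cytotoxicity, read by MTT assay, with a stated time of 24 h (a higher number here means a weaker inhibitor, a lower number a stronger inhibitor), compound 1 (`CN1CCN(CCCCCOc2c(Br)cc(Br)cc2Oc2ccc(Br)cc2Br)CC1`) gives 49.1 ug/mL and compound 2 (`CC(C)(C)OC(=O)N1CCN(CCCCCOc2c(Br)cc(Br)cc2Oc2ccc(Br)cc2Br)CC1`) gives 35.5 ug/mL as its value, so compound 2 lies within the scatter of compound 1 and the two cannot be ranked. Compound 3 (`Brc1ccc(Oc2cc(Br)cc(Br)c2OCCCCCN2CCN(C/C=C/c3ccccc3)CC2)c(Br)c1`) carries 3-phenylprop-2-en-1-yl in place of tert-butoxycarbonyl on an amine nitrogen in a ring, counted as 3-phenylprop-2-en-1-yl in place of tert-butoxycarbonyl on an amine nitrogen in a ring in full. For the measured compounds named here, the only measured step at this nitrogen is a 1.4-fold lower number from compound 1 to compound 2 (0.14 log units; within the scatter) for tert-butoxycarbonyl in place of methyl, and it stays within the scatter. Going by the values given here, no measured compound carries 3-phenylprop-2-en-1-yl, so the guide is indirect. With only a 1.4-fold lower number from compound 1 to compound 2 (0.14 log units; within the scatter) to go on, a shift beyond the scatter in this assay is not expected, and no direction is favoured. The expected change is a 1.1-fold lower number from compound 2 to compound 3 (0.03 log units; within the scatter) at the middle of the estimate. Compound 3 is estimated at 33 ug/mL with an expected range from 14 ug/mL to 70 ug/mL in this series.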

Compound 3, half-maximal inhibitory concentration: 32.7 ug/mL
For compound 3 the middle estimate is 1.0-fold (0.00 log units) above the measured one; measured number inside the range.
By their numbers in this assay, from the lowest: compounds 3, 2 and 1 (each within the scatter of the next).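

In this assay, the step of a 1.1-fold lower number from compound 2 to compound 3 (0.04 log units; within the scatter) for 3-phenylprop-2-en-1-yl in place of tert-butoxycarbonyl shows that a six-membered aromatic ring of carbon only can enter on this amine nitrogen in a ring, with no hydrogen-bond acceptors left in the group, and the number stays within the scatter. The step of a 1.5-fold lower number from compound 1 to compound 3 (0.18 log units; within the scatter) for 2-phenylethenyl in place of hydrogen on the saturated chain carbon bound to that nitrogen also stays within the scatter, so three different groups at this nitrogen cannot be ranked. Nothing available bears on why these numbers stay so close.

Still open, from the compounds shown here alone, is whether any group at this nitrogen moves the number beyond the scatter, for instance hydrogen, a carboxylic acid or a hydroxyethyl group. Also open, going by these compounds, are a shorter or longer chain to the shared core and chlorine in place of bromine on that core.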